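The source may report more compounds than this note shows. Statements on the series, on what has been measured and on what is new or still open speak of the compounds shown alone.

Measured so far:
compound 1 `Cc1ccccc1Oc1ccc(N2C[C@@H](C(F)(F)F)C[C@H]2CC(=O)O)cc1` — 330 nM
compound 2 `Cc1ccccc1Oc1ccc(N2CCC[C@H]2CC(=O)O)cc1` — 5600 nM

Notes. Within the data shown here, in a functional assay on cells for agonist activity at Free fatty acid receptor 1 (Mus musculus), read by FLIPR and calcium flux, with a stated time of 100 s (a higher number here means that more compound is needed for the effect, a lower number that less compound is needed), compound 1 gives 330 nM, the lower of the two numbers so far. Compound 2 stands nearest; the change of a 17-fold higher number from compound 1 to compound 2 (1.23 log units; beyond the scatter) shows how much the trifluoromethyl on the saturated ring contributes within this pair.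

The next compound, compound 3 `O=C(O)C[C@@H]1C[C@H](C(F)(F)F)CN1c1ccc(Oc2ccccc2OC(F)(F)F)cc1`, keeps that trifluoromethyl and the shared core of compound 1 and alters the other end: trifluoromethoxy in place of methyl on an aromatic carbon. Among the measured compounds shown here, no measured step touches this aromatic position; the only step available, from compound 1 to compound 2, concerns the saturated ring and so does not bear on the change to compound 3. With nothing in this assay to guide the direction, the working expectation is a step in this assay of no more than the usual scatter, in either direction. Compound 3 is therefore estimated at 300 nM, with a range of 90 nM to 1000 nM, which corresponds to an expected step of a 1.1-fold lower number from compound 1 to compound 3 (0.04 log units; within the scatter) from compound 1. For the measured compounds named here, the range is deliberately wide, since the series gives no precedent for this position.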

Compound 3, half-maximal effective concentration: 740 nM
Beside the measured number, compound 3's estimate is 2.5-fold (0.39 log units) below it; measured number inside the range.
By their numbers in this assay, from the lowest: compound 1; then compound 3; then compound 2.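

In this assay, the aromatic carbon ortho to a large group now has its first reading: trifluoromethoxy in place of methyl gives a 2.2-fold higher number from compound 1 to compound 3 (0.35 log units; beyond the scatter). This position responds to substitution, though the step is modest beside a 17-fold higher number from compound 1 to compound 2 (1.23 log units; beyond the scatter), the change on the saturated ring, so within these pairs the saturated ring carbon is the more sensitive of the two places. Enlarging the substituent from 1 heavy atom to 5 heavy atoms and adding a hydrogen-bond acceptor does not remove agonist activity, but nothing measured here accounts for the direction or size of the step.

With only methyl and trifluoromethoxy at this aromatic carbon, the contributions of the added oxygen and the three fluorine atoms cannot be separated, and a methoxy group or a chlorine atom there would be the informative comparison. As far as these compounds go, it also remains open whether the trifluoromethyl on the saturated ring contributes as much alongside trifluoromethoxy as it does alongside methyl, and whether the step seen here would carry over to the mouse receptor's counterpart in other species.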